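Swapping the acyl cap on a quinolinyl hydroxamate

A few compounds are considered here, and "the series" means these few. Any claim that something is new, unique, unknown or untested is made for them only; others in the source may bear on it.

Three hydroxamic acids sharing one core were examined in a functional assay on NFF cells (Homo sapiens) for antiproliferative activity; on this read-out higher numbers stand for weaker inhibition and lower numbers for stronger inhibition. Compound 1 `O=C(CCCCC[C@H](NC(=O)OCc1ccccc1)C(=O)NCc1ccccc1)NO` gives 1520 nM. Compound 2 `O=C(CCCCC[C@H](NC(=O)c1ccc(C(F)(F)F)cc1)C(=O)NCc1ccccc1)NO` gives 1610 nM. Compound 3 `O=C(CCCCC[C@H](NC(=O)c1ccc(C(F)(F)F)cc1)C(=O)Nc1cccc2cccnc12)NO` gives 696 nM, the lowest of the three numbers.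

Two single changes connect these compounds. The first, (benzyloxy in place of 4-(trifluoromethyl)phenyl on a carbonyl carbon), produced a step of a 1.1-fold lower number from compound 2 to compound 1 (0.02 log units; within the scatter). The second, (quinolin-8-yl in place of benzyl on an amide-type nitrogen), produced a step of a 2.3-fold lower number from compound 2 to compound 3 (0.36 log units; beyond the scatter). Compound 3 thus stands apart from compound 1 and compound 2 by amounts beyond the scatter, while compound 1 and compound 2 sit within the scatter of each other.

Compound 4 `O=C(CCCCC[C@H](NC(=O)OCc1ccccc1)C(=O)Nc1cccc2cccnc12)NO` has not yet been measured in this assay. It differs from compound 3 by benzyloxy in place of 4-(trifluoromethyl)phenyl on a carbonyl carbon, which is the same change that was made from compound 2 to compound 1, where it gave a 1.1-fold lower number from compound 2 to compound 1 (0.02 log units; within the scatter). Compound 4 and compound 3 share the quinolin-8-yl amide that sets compound 3 apart; the cores of compound 3 and compound 2 differ as told by quinolin-8-yl in place of benzyl on an amide-type nitrogen.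

Because the earlier step of a 1.1-fold lower number from compound 2 to compound 1 (0.02 log units; within the scatter) lay within the scatter, compound 4 is expected to show a step of about a 1.1-fold lower number from compound 3 to compound 4 (0.03 log units; within the scatter) from compound 3. Compound 4 is therefore estimated at 650 nM, with a plausible range from 300 nM to 1400 nM.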

Compound 4, half-maximal inhibitory concentration: 452 nM
Beside the measured number, compound 4's estimate is 1.4-fold (0.16 log units) above it, within the range that was stated.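

In this assay, benzyloxy in place of 4-(trifluoromethyl)phenyl on a carbonyl carbon gives a 1.5-fold lower number from compound 3 to compound 4 (0.19 log units; within the scatter), and this change behaves the same way on the benzyl amide and the quinolin-8-yl amide within the scatter of two such steps: the same change on two cores in this assay, a 1.1-fold lower number (0.02 log units; within the scatter) from compound 2 to compound 1 and a 1.5-fold lower number (0.19 log units; within the scatter) from compound 3 to compound 4, 1.5-fold (0.16 log units) apart, within the scatter of two such steps. The other change also carries over, since quinolin-8-yl in place of benzyl on an amide-type nitrogen, now with the benzyloxy group in the molecule, gives a 3.4-fold lower number from compound 1 to compound 4 (0.53 log units; beyond the scatter), and the two readings of this step agree: the same change on two cores in this assay, a 2.3-fold lower number (0.36 log units; beyond the scatter) from compound 2 to compound 3 and a 3.4-fold lower number (0.53 log units; beyond the scatter) from compound 1 to compound 4, 1.5-fold (0.16 log units) apart, within the scatter of two such steps. Among these four compounds, then, the two changes read as roughly independent, with the amide change producing the steps beyond the scatter and the carbonyl change producing none, but this rests on only one pair of steps for each change and does not show why the steps agree or that they would agree on any other core.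

The compounds shown leave open whether this agreement would hold with an amine or a carboxylic acid on the capping group in place of these two groups. On these data alone, it also remains open whether a longer chain leading to the hydroxamic acid would preserve the step seen with the quinolin-8-yl amide.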